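The compounds below may be only part of what the source reports. "The series", "measured", "known", "first", "only" and "open" are said of these compounds alone.

Measured compounds:
compound 1 `Oc1nc2nonc2nc1Nc1ccc(OCC(F)(F)F)c(F)c1` with 10400 nM
compound 2 `Oc1nc2nonc2nc1Nc1ccc(OCc2ccccc2)cc1` with 2400 nM

In an assay on mitochondria from L6 cells (Rattus norvegicus) for activation, with a stated time of 90 min (on this read-out lower numbers stand for an effect already at smaller amounts and higher numbers for an effect only at larger amounts of compound), compound 2 gives the lower of the two numbers, and compound 1 gives the higher one, a gap beyond the usual scatter. Compound 3 `CCCCCCc1ccc(Nc2nc3nonc3nc2O)cc1` has not been measured. It differs from compound 2 in one place: hexyl in place of benzyloxy on an aromatic carbon. For the measured compounds named here, no pair of measured compounds shows what such a change does, so compound 3 is expected to stay near compound 2, with an estimated step of a 1.3-fold higher number from compound 2 to compound 3 (0.10 log units; within the scatter) that lies within the scatter. For compound 3 the estimate is 3000 nM, within a range from 800 nM to 12000 nM.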

Compound 3, half-maximal effective concentration: 4700 nM
Compound 3: middle estimate off by 1.6-fold (0.19 log units), on the low side, and the stated range covers the measured number.
By their numbers in this assay, from the lowest: compounds 2 and 3 (each within the scatter of the next); then compound 1.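

In this assay, hexyl in place of benzyloxy gives a 2.0-fold higher number from compound 2 to compound 3 (0.29 log units; within the scatter) and so leaves the two compounds indistinguishable. This position on the aromatic ring therefore accepts a chain with no ring and no hydrogen-bond acceptor, and the number stays in the same range. Nothing measured explains this result. On these data alone, the ring and the oxygen leave together, and what each contributes alone stays open. Also open, as far as these compounds go, is whether an amine, a carboxylic acid or a longer chain here would keep the number in this range.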